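The source may report more compounds than this note shows. Statements on the series, on what has been measured and on what is new or still open speak of the compounds shown alone.

Compound 1 `Cc1ncnc2c1c(I)cn2[C@@H]1O[C@H](CO)[C@@H](O)[C@H]1O` in a functional assay on K562 cells (Homo sapiens), read by MTT assay, with a stated time of 72 h (on this read-out higher numbers stand for weaker inhibition and lower numbers for stronger inhibition), gives > 20000 nM, which is a limit of the assay.
Compound 2 `CNc1ncnc2c1c(I)cn2[C@@H]1O[C@H](CO)[C@@H](O)[C@H]1O` in this assay gives > 20000 nM, which is likewise a limit.

Compound 2 therefore stands only at a limit in this assay, and the whole set rests there: the limit of > 20000 nM in this assay, at which 2 of the 2 values shown sit. Among the compounds with values here, the one measured step, a step that the two limits leave unreadable from compound 1 to compound 2, shows nothing about size or direction. Compound 3 `CNc1ncnc2c1c(-c1ccco1)cn2[C@@H]1O[C@H](CO)[C@@H](O)[C@H]1O` differs from compound 2 by furan-2-yl in place of iodo on an aromatic carbon. Within the data shown here, no measured step bears on this change, and compound 2 itself gives no number, so neither the size nor the direction of the step in this assay can be anticipated from what has been measured. Compound 3 is estimated at 8000 nM, with a range from 1000 nM to 20000 nM, which would mean an expected step of an at least 2.5-fold lower number from compound 2 to compound 3 (0.39 log units; beyond the scatter).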

Compound 3, half-maximal inhibitory concentration: 15100 nM
Compound 3: middle estimate off by 1.9-fold (0.28 log units), on the low side, and the stated range covers the measured number.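

Within the data shown here, with furan-2-yl on this aromatic carbon, compound 3 gives 15100 nM in this assay, the first actual number in the set. As far as these compounds go, the change gives an at least 1.3-fold lower number from compound 2 to compound 3 (0.12 log units; that floor lies within the scatter), so the real size of the step remains unknown, though the position can carry a group larger than iodo and still yield a readable value. The rest of the set stays out of reach: the limit of > 20000 nM in this assay, at which 2 of the 3 values shown sit.

From the compounds shown here alone, whether phenyl or thiophen-2-yl at this position would lower the number further remains open. So does whether furan-2-yl would give a readable value with methyl in place of methylamino.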